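The source may report more compounds than this note shows. Statements on the series, on what has been measured and on what is new or still open speak of the compounds shown alone.

Measured so far:
compound 1 `CC1CCN(c2nc(C(F)(F)F)ccc2CNC(=O)C(C)c2ccc(N(C)S(C)(=O)=O)c(F)c2)CC1` — 55.5 nM
compound 2 `CCN(c1ccc(C(C)C(=O)NCc2ccc(C(F)(F)F)nc2N2CCC(C)CC2)cc1F)S(C)(=O)=O` — 22.7 nM

Compound 2 is the lower of the two numbers in an assay on cells for antagonist activity at transient receptor potential cation channel subfamily V member 1 (Homo sapiens), read by FLIPR and calcium flux, with a stated time of 15 min; a higher number here means a weaker inhibitor, a lower number a stronger inhibitor: the step of a 2.4-fold lower number from compound 1 to compound 2 (0.39 log units; beyond the scatter) shows the gain from compound 1 to compound 2. Compound 3 `C=CC(=O)N(c1ccc(C(C)C(=O)NCc2ccc(C(F)(F)F)nc2N2CCC(C)CC2)cc1F)S(C)(=O)=O` differs from compound 2 by vinylcarbonyl in place of ethyl on a sulfonamide nitrogen. Within the data shown here, no measured step touches this spot in this way; the only step, a 2.4-fold lower number from compound 1 to compound 2 (0.39 log units; beyond the scatter), changed a chain carbon on the same nitrogen and was modest. With nothing closer to lean on, the expected step of a 1.8-fold higher number from compound 2 to compound 3 (0.25 log units; within the scatter) is small and uncertain. Compound 3 is therefore estimated at 40 nM, within 10 nM to 160 nM.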

Compound 3, inhibition constant: 2.4 nM
The estimate for compound 3 lay 17-fold (1.22 log units) above the measured number, outside the stated range (below it).
By their numbers in this assay, from the lowest: compound 3; then compound 2; then compound 1.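

Placing vinylcarbonyl on the sulfonamide nitrogen in this assay gives a 9.5-fold lower number from compound 2 to compound 3 (0.98 log units; beyond the scatter), so this position accepts more than a small alkyl group. Measured against the methyl group, the same change gives a 23-fold lower number from compound 1 to compound 3 (1.36 log units; beyond the scatter), a large step at a position where the earlier change was modest. Nothing available here accounts for the size of this drop.

On these data alone, whether the carbonyl alone or the vinyl group with it carries the gain remains open; an acetyl group on this nitrogen would separate the two. A propyl group would show whether lengthening the alkyl chain continues to lower the number.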